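Growth inhibition after an ethyl to bromo swap

A few compounds are considered here, and "the series" means these few. Any claim that something is new, unique, unknown or untested is made for them only; others in the source may bear on it.

Measured in a functional assay on HCT-116 cells (Homo sapiens) for inhibition, read by CCK-8 assay, with a stated time of 72 h, tested at 2 uM (on this read-out higher numbers stand for more inhibition of growth at the one concentration tested and lower numbers for less inhibition of growth), the compounds give:
- compound 1 `COc1ccc(SCc2ccc(/C=C/C(=O)Nc3ccccc3N)cc2)cc1OC` with 12.9%
- compound 2 `CCc1ccc(SCc2ccc(C(=O)Nc3ccccc3N)cc2)cc1` with 40.7%
- compound 3 `Nc1ccccc1NC(=O)/C=C/c1ccc(CSc2ccc(C(F)(F)F)cn2)cc1` with 4.42%

Compound 2 stands highest of these three numbers, beyond the scatter above both compound 1 and compound 3. Compound 4 `Nc1ccccc1NC(=O)c1ccc(CSc2ccc(Br)cc2)cc1` keeps the core of compound 2 and differs in one place. The change bromo in place of ethyl on an aromatic carbon amounts to bromo in place of ethyl on an aromatic carbon. Within the data shown here, only one measured step bears on it, and only loosely. The step of a number 8.5 percentage points lower from compound 1 to compound 3 (within the scatter) exchanges 5-(trifluoromethyl)pyridin-2-yl for 3,4-dimethoxyphenyl on a sulfur, on the core of compound 1. Among the measured compounds shown here, no measured step exchanges ethyl or bromo, so the guidance is thin and the range must stay wide. No step beyond the scatter is expected in this assay in either direction. The expected change is a number 2.7 percentage points lower from compound 2 to compound 4 (within the scatter) as estimated here. Compound 4 is estimated at 38% in this assay with an expected range from 20% to 58% for the coming measurement.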

Compound 4, percent growth inhibition at one concentration: 9.96%
Compound 4: the middle estimate sits 28 percentage points above what was measured; the measured number lies below the stated range.
By their numbers in this assay, from the lowest: compounds 3, 4 and 1 (each within the scatter of the next); then compound 2.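

In this assay, the aromatic carbon para to a large group proves sensitive to a small exchange: bromo in place of ethyl gives a number 30.7 percentage points lower from compound 2 to compound 4 (beyond the scatter). The earlier step at the sulfur, a number 8.5 percentage points lower from compound 1 to compound 3 (within the scatter), showed no such change, though it was a different exchange on the core of compound 1, so the two steps say nothing about each other's size. Nothing available here accounts for the size of the new step.

On these data alone, whether a propyl chain, an amine or a carboxylic acid on this carbon would stay close to compound 2 or to compound 4 remains open. Also open, as far as these compounds go, is whether the same exchange of ethyl for bromo would carry over to the core of compound 1.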